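Bromo in Place of 4-Fluorophenyl: Little Change Expected

The compounds below may be only part of what the source reports. "The series", "measured", "known", "first", "only" and "open" are said of these compounds alone.

Compound 1 `C=CCOc1c(C)c(C)c2c(c1C)CCC(C)(COc1cccc(/C=C3\SC(=O)NC3=O)c1)O2` and compound 2 `CC(C)=CCOc1c(C)c(C)c2c(c1C)CCC(C)(COc1ccc(/C=C3\SC(=O)NC3=O)cc1-c1ccc(F)cc1)O2` share the same core. In a functional assay on MCF7 cells (Homo sapiens), tested at 5 uM (a lower number here means a stronger effect, a higher number a weaker effect of the compound at the concentration tested), compound 1 gives 92%, and compound 2 gives 92%, so compound 2 stands level with compound 1 within the usual scatter. Compound 3 `CC(C)=CCOc1c(C)c(C)c2c(c1C)CCC(C)(COc1ccc(/C=C3\SC(=O)NC3=O)cc1Br)O2` follows from compound 2 by one change: bromo in place of 4-fluorophenyl on an aromatic carbon. Because compound 2 gives 92%, only a weak effect is in view, and the expected step of a number 2 percentage points lower from compound 2 to compound 3 (within the scatter) is none beyond the scatter. For compound 3 the estimated value is 90%, with a range from 75% to 102%.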

Compound 3, a percentage reported as activity, at one concentration (the size of the read-out at that concentration, not a potency): 84%
The estimate for compound 3 lay 6 percentage points above the measured number; measured number inside the range.
By their numbers in this assay, from the lowest: compounds 3, 1 and 2 (each within the scatter of the next).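

In this assay, bromo in place of 4-fluorophenyl brings a number 8 percentage points lower from compound 2 to compound 3 (within the scatter). So this aromatic carbon can lose a whole six-membered ring, going from 7 heavy atoms to 1, without a shift beyond the scatter, and the effect stays weak with either group. No measurement shown explains this small step. As far as these compounds go, whether an amine or a carboxylic acid on this carbon would move the number beyond the scatter remains open. So does whether a stronger effect can be reached through this position at all.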